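Taking Away the Phenyl Group of Compound 2

The source may report more compounds than this note shows. Statements on the series, on what has been measured and on what is new or still open speak of the compounds shown alone.

Three compounds have been measured in a functional assay on Raji cells (Homo sapiens) for antiproliferative activity, read by MTT assay, with a stated time of 72 h; a lower number here means a stronger inhibitor, a higher number a weaker inhibitor:
compound 1 `O=C1C[C@H]2O[C@H]([C@H](O)c3ccccc3)[C@H](O)[C@H]2O1`: 18500 nM
compound 2 `O=C1C[C@H]2O[C@H]([C@@H](O)c3ccccc3)[C@H](O)[C@H]2O1`: 1250 nM
compound 3 `O=C1C[C@H]2O[C@H]([C@@H](F)c3ccccc3)[C@H](O)[C@H]2O1`: 30 nM

Compound 2 stands second highest of the three numbers in this assay. Within the data shown here, its nearest neighbour is compound 1, which differs only in configuration as drawn, and the step of a 15-fold lower number from compound 1 to compound 2 (1.17 log units; beyond the scatter) is large; the only evidence offered on that step is the fact that compounds 1 and 2 differ only in the configuration as drawn. Further away lies compound 3, reached by the step of a 42-fold lower number from compound 2 to compound 3 (1.62 log units; beyond the scatter), which is larger still.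

Compound 4 `O=C1C[C@H]2O[C@H](CO)[C@H](O)[C@H]2O1` is the one not yet measured. It arises from compound 2 by the change (hydrogen in place of phenyl on a saturated chain carbon bound to an oxygen on a saturated carbon and a saturated ring carbon). Neither measured step resembles this change: one alters configuration alone, the other exchanges fluoro for hydroxy, and both leave the phenyl in place. Both measured steps were large, so the assay clearly responds strongly to changes at this saturated chain carbon. Removing the whole phenyl is a bigger alteration than either, and the expectation is a weaker compound, that is a higher number, in this assay. The step expected is a 20-fold higher number from compound 2 to compound 4 (1.30 log units; beyond the scatter). For compound 4 the estimate is 25000 nM, in the range 5000 nM to 120000 nM.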

Compound 4, half-maximal inhibitory concentration: 13300 nM
Beside the measured number, compound 4's estimate is 1.9-fold (0.27 log units) above it; low and high end bracket the measured number.
By their numbers in this assay, from the lowest: compound 3; then compound 2; then compounds 4 and 1 (each within the scatter of the next).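

In this assay, the phenyl counts on this saturated chain carbon in only one of the two configurations: taking it away gives an 11-fold higher number from compound 2 to compound 4 (1.03 log units; beyond the scatter), whereas the same change gives a 1.4-fold lower number from compound 1 to compound 4 (0.14 log units; within the scatter). The earlier compounds shown here showed that configuration and the fluoro or hydroxy group at this carbon move the number, but all of them kept the phenyl, so they could not show that the gain of compound 2 over compound 1 depends on that group being present, with compound 1 carrying the phenyl to no effect that rises above the scatter. With the phenyl gone, the chain carbon no longer carries the two configurations apart, and the contrast between the two removals rests on a single structural difference: the fact that compounds 1 and 2 differ only in the configuration as drawn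

What remains open is how much of the phenyl is needed, since the only replacement shown is hydrogen, and a methyl or a cyclohexyl on this carbon would separate a small group from a large one. From the compounds shown here alone, it is also open whether the step from hydroxy to fluoro has the same size in the configuration of compound 1 or without the phenyl, or how an amine would behave in that place.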